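The source may report more compounds than this note shows. Statements on the series, on what has been measured and on what is new or still open speak of the compounds shown alone.

Measured compounds so far:

- Compound 1, `COc1cc2c(Oc3ccc(NC(=O)c4nn(-c5ccccc5C(F)(F)F)c(=O)cc4C)cc3F)ccnc2cc1OCCCN1CCCCC1`: in a functional assay on NCI-H460 cells (Homo sapiens) for inhibition, read by MTT assay, with a stated time of 72 h (a higher number here means a weaker inhibitor, a lower number a stronger inhibitor), compound 1 gives 210 nM
- Compound 2, `COc1cc2c(Oc3ccc(NC(=O)c4nn(-c5ccccc5C(F)(F)F)c(=O)cc4C)cc3F)ccnc2cc1OCCCN1CCC(C)CC1`: in this assay compound 2 gives 200 nM

Compound 2 has the lowest number of the two, but only just: the step of a 1.1-fold lower number from compound 1 to compound 2 (0.02 log units; within the scatter) is within the scatter, so compound 1 and compound 2 cannot be told apart on these numbers.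

The next compound, compound 3, `COc1cc2c(Oc3ccc(NC(=O)c4nn(-c5ccccc5OC(F)(F)F)c(=O)cc4C)cc3F)ccnc2cc1OCCCN1CCC(C)CC1`, keeps everything in compound 2 except one part of a side ring: trifluoromethoxy in place of trifluoromethyl on an aromatic carbon. For the measured compounds named here, none of the measured steps touches this part of the molecule. Going by the values given here, the single measured step, a 1.1-fold lower number from compound 1 to compound 2 (0.02 log units; within the scatter), sits on the saturated ring at the far end and was within the scatter, so it gives no guide on how this aromatic substituent behaves. With nothing measured to anchor the change, the plain expectation is a step of no more than the usual scatter in this assay, in either direction, estimated as a 1.3-fold higher number from compound 2 to compound 3 (0.10 log units; within the scatter). Compound 3 is therefore expected at about 250 nM, with a range from 100 nM to 700 nM.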

Compound 3, half-maximal inhibitory concentration: 290 nM
Compound 3: the middle estimate sits 1.2-fold (0.06 log units) below what was measured; measured number inside the range.
By their numbers in this assay, from the lowest: compounds 2, 1 and 3 (each within the scatter of the next).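

In this assay, putting trifluoromethoxy in place of trifluoromethyl on this aromatic carbon, ortho to a large group, gives a 1.5-fold higher number from compound 2 to compound 3 (0.16 log units; within the scatter) and so leaves compound 2 and compound 3 indistinguishable on these numbers. For the compounds shown here, this is the first measured change on the side ring rather than on the saturated ring at the far end, and it shows that 2-(trifluoromethyl)phenyl can become 2-(trifluoromethoxy)phenyl, a swap that adds one oxygen atom, without a step beyond the scatter. No accompanying measurement bears on what lies behind this result, so the numbers describe only how far the read-out moved.

Both compounds carry a fluorinated group at this carbon, so the compounds shown leave open what a plain hydrogen, a methoxy group, an amine or a carboxylic acid there would give. As far as these compounds go, it is also open whether the same exchange would read alike on compound 1, which has hydrogen in place of the methyl on the saturated ring.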